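A Methyl on the Benzyl Ring of Compound 4

A few compounds are considered here, and "the series" means these few. Any claim that something is new, unique, unknown or untested is made for them only; others in the source may bear on it.

Three measured compounds share one core and differ only in the aryl group on the amine nitrogen. Compound 1 `c1ccc(CCCN2CCN(CCN(Cc3ccccc3)c3ccccn3)CC2)cc1` carries pyridin-2-yl there and in an assay on HEK293 cells for inhibition of sodium-dependent dopamine transporter (Homo sapiens) (on this read-out lower numbers stand for lower potency and higher numbers for higher potency (the scale is a negative logarithm)), compound 1 gives 6.91. Compound 2 `COc1ccc(N(CCN2CCN(CCCc3ccccc3)CC2)Cc2ccccc2)cc1`, with 4-methoxyphenyl in that place, gives 6.67, and a number 0.24 log units lower from compound 1 to compound 2 (within the scatter). Compound 3 `c1ccc(CCCN2CCN(CCN(Cc3ccccc3)c3ccccc3)CC2)cc1`, with a plain phenyl, gives 5.96, the lowest of the three numbers: a number 0.95 log units lower from compound 1 to compound 3 (beyond the scatter), and a number 0.71 log units lower from compound 2 to compound 3 (beyond the scatter).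

Compound 4 `Cc1ccc(CN(CCN2CCN(CCCc3ccccc3)CC2)c2ccccc2)cc1` keeps the phenyl of compound 3 and changes the benzyl group instead: methyl in place of hydrogen on an aromatic carbon. Going by the values given here, no measured step touches the benzyl ring, so the closest guide is the only substituent change on an aromatic carbon, a number 0.71 log units lower from compound 2 to compound 3 (beyond the scatter), which concerns the other ring and a different group. Among the compounds with values here, that step was modest, and a methyl placed elsewhere offers no firmer precedent, so the step from compound 3 to compound 4 is expected to be small, a number 0.24 log units higher from compound 3 to compound 4 (within the scatter), possibly not beyond the scatter. Compound 4 is therefore estimated at 6.2, with a range from 5.6 to 6.8.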

Compound 4, logarithm of the reciprocal of the active concentration, log(1/C): 5.49
The estimate for compound 4 lay 0.71 log units above the measured number; the whole stated range lies above it.
By their numbers in this assay, from the lowest: compound 4; then compound 3; then compounds 2 and 1 (each within the scatter of the next).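

In this assay, going by these compounds alone, the benzyl ring comes into play for the first time, and methyl in place of hydrogen gives a number 0.47 log units lower from compound 3 to compound 4 (beyond the scatter) as a modest step that is still larger than the usual scatter, so this carbon, para to a large group, is not a spot where a change passes unnoticed. Within the data shown here, the only earlier change of a substituent on an aromatic carbon, on the other ring, was hydrogen in place of methoxy, with a number 0.71 log units lower from compound 2 to compound 3 (beyond the scatter) as its step, so there the substituted compound held the higher number, whereas here the substituted compound holds the lower one, and a substituent on an aromatic carbon therefore does not push the number the same way on both rings. No other measurement bears on this result, so the reason for the drop stays unknown.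

On these data alone, whether chloro, hydroxyl or an amine on the same carbon would lower the number as methyl does remains open, as does the effect of a methyl on the other carbons of the benzyl ring. As far as these compounds go, it is also open whether the 4-methylbenzyl group would cost as much with pyridin-2-yl or 4-methoxyphenyl on the amine nitrogen.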